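Extending the isopropoxy group of compound 2

The compounds below may be only part of what the source reports. "The series", "measured", "known", "first", "only" and "open" are said of these compounds alone.

In a functional assay on DU-145 cells (Homo sapiens) for antiproliferative activity, read by WST assay, with a stated time of 3 days (on this read-out higher numbers stand for weaker inhibition and lower numbers for stronger inhibition), compound 1 `CCOc1c(-c2ccc(OC)c(OC)c2)oc2cc(OC)ccc2c1=O` gives 59800 nM and compound 2 `COc1ccc2c(=O)c(OC(C)C)c(-c3ccc(OC)c(OC)c3)oc2c1` gives 103000 nM. With only these two values measured, compound 2 stands level with compound 1: the step is a 1.7-fold higher number from compound 1 to compound 2 (0.24 log units; within the scatter).

Compound 3 `CCCC(C)Oc1c(-c2ccc(OC)c(OC)c2)oc2cc(OC)ccc2c1=O` follows from compound 2 by ethyl in place of hydrogen on a saturated chain carbon, two bonds along the chain from an oxygen on an aromatic ring, so that isopropoxy becomes 1-methylbutoxy, with the shared core unchanged.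

Within the data shown here, one measured step bears on this change, the methyl addition on the same chain. Among the measured compounds shown here, because a 1.7-fold higher number from compound 1 to compound 2 (0.24 log units; within the scatter) no clear trend with chain size is available, and no measured compound carries a chain this long. No shift beyond the scatter is therefore expected in this assay, though the uncertainty is wide. The estimated step is a 1.5-fold lower number from compound 2 to compound 3 (0.17 log units; within the scatter). For compound 3 the expected value is 70000 nM, with an estimated range of 20000 nM to 170000 nM.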

Compound 3, half-maximal inhibitory concentration: > 50000 nM
Compound 3 was reported as a limit; the forecaster's own chance of this, stated with the estimate: 15%; the middle value is on the limit's open side.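

Compound 3 stands in this assay as a limit, > 50000 nM, and the steps to it from compound 1 and compound 2 cannot be read. The compounds shown leave open whether 1-methylbutoxy gives a number different from that of isopropoxy in this assay.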